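Ethynyl for ethyl on the biaryl amide core

A few compounds are considered here, and "the series" means these few. Any claim that something is new, unique, unknown or untested is made for them only; others in the source may bear on it.

The series is followed in an assay (Canis lupus familiaris) for binding affinity to platelet-activating factor receptor (Homo sapiens), read by radioligand binding; on this read-out higher numbers stand for weaker inhibition and lower numbers for stronger inhibition. Compound 1 `COc1ccc(-c2ccc(C(=O)NCCCCc3cccnc3)cc2OC)cc1OC` gives 300 nM. Compound 2 `COc1cccc(-c2ccc(C(=O)N[C@H](C)CCCc3cccnc3)cc2)c1` gives 20 nM. Compound 3 `CCc1cc(C(=O)N[C@H](C)CCCc2cccnc2)ccc1-c1ccc(OC)c(OC)c1` gives 4 nM, the lowest of the three numbers; compound 2 stands nearest to it and compound 1 furthest, and both gaps lie beyond the scatter of this assay. Not yet measured is compound 4 `C#Cc1cc(C(=O)N[C@H](C)CCCc2cccnc2)ccc1-c1ccc(OC)c(OC)c1`, which differs from compound 3 in one place: ethynyl in place of ethyl on an aromatic carbon. Among the compounds with values here, no measured pair shows this exchange, so its effect cannot be read from the numbers at hand. The rest of the molecule is that of compound 3. A small step in either direction, or none beyond the scatter, is expected from such an exchange. The step from compound 3 to compound 4 is estimated at a 1.5-fold higher number from compound 3 to compound 4 (0.18 log units; within the scatter). Compound 4 is expected to give about 6 nM in this assay, with a range from 2 nM to 20 nM.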

Compound 4, half-maximal inhibitory concentration: 5 nM
For compound 4 the middle estimate is 1.2-fold (0.08 log units) above the measured one; measured number inside the range.
By their numbers in this assay, from the lowest: compounds 3 and 4 (each within the scatter of the next); then compound 2; then compound 1.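

In this assay, ethynyl in place of ethyl on the aromatic carbon ortho to a 3,4-dimethoxyphenyl group gives a 1.3-fold higher number from compound 3 to compound 4 (0.10 log units; within the scatter). Within the data shown here, this is the first pair that differs in one place, and it shows that, on this core, the two groups cannot be told apart at this position, even though ethynyl brings a triple bond that ethyl lacks. No available evidence bears on why the two groups read alike.

Still open, from the compounds shown here alone, is whether a nitrile, an amine, a carboxylic acid or a longer chain such as propyl at this position would also stay within the scatter of compound 3. Also open, going by these compounds, is whether the same exchange reads alike on a core with a different amide side chain, such as the unbranched butyl chain of compound 1.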